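The source may hold more compounds than are shown below. What is called first, only, known or untested is meant among the compounds shown, and "the series" means these compounds.

Compound 1 `Cn1cc(C2=C(c3nn(CCn4ccnc4)c4ncccc34)C(=O)NC2=O)c2ccccc21` and compound 2 `CN(C)CCCn1nc(C2=C(c3cn(C)c4ccccc34)C(=O)NC2=O)c2cccnc21` open the series. In a functional assay on ECa-109 cells (Homo sapiens) for antiproliferative activity, read by MTT assay, with a stated time of 48 h (on this read-out higher numbers stand for weaker inhibition and lower numbers for stronger inhibition), compound 1 gives > 100000 nM, a limit of the assay. In this assay compound 2 gives > 100000 nM, likewise a limit. Among the measured compounds shown here, the step that the two limits leave unreadable from compound 1 to compound 2 therefore cannot be sized, and every value so far sits at the limit of > 100000 nM in this assay, at which 2 of the 2 values shown sit. Compound 3 `CN(C)CCCn1nc(C2=C(c3cn(C)c4ccccc34)C(=O)N(c3ccccc3)C2=O)c2cccnc21` carries the change (phenyl in place of hydrogen on an amide-type nitrogen in a ring). For the measured compounds named here, no measured step touches this position, so no direction can be read from the data. Compound 3 is expected to give 100000 nM, within 30000 nM to 300000 nM, the estimated step of a number no higher from compound 2 to compound 3 (the limit leaves the size open) being no more than scatter.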

Compound 3, half-maximal inhibitory concentration: 5840 nM
For compound 3 the middle estimate is 17-fold (1.23 log units) above the measured one; measured number outside the range, below it.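

In this assay, among the compounds shown here, phenyl in place of hydrogen on the amide-type nitrogen gives an at least 17-fold lower number from compound 2 to compound 3 (1.23 log units; beyond the scatter), so this nitrogen is the first position where a change yields a readable step. On these data alone, the step is a bound, and its full size stays open: the limit of > 100000 nM in this assay, at which 2 of the 3 values shown sit. Compound 3 is also the only compound shown with a value that is not a limit. As far as these compounds go, what a methyl or benzyl group on this nitrogen would give remains open. So does whether phenyl there has a comparable effect with the 1H-imidazol-1-yl chain of compound 1.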